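From Isopropyl to Propyl on the Amide Nitrogen

The source may report more compounds than this note shows. Statements on the series, on what has been measured and on what is new or still open speak of the compounds shown alone.

In a functional assay on the whole organism with Mus musculus as the target (on this read-out higher numbers stand for an effect only at larger amounts of compound and lower numbers for an effect already at smaller amounts), compound 2 `CC(C)NC(=O)/C=C1\CCc2ccc(F)cc21` gives 96 mg/kg. Compound 3 `CC(C)NC(=O)/C=C1\CCc2c(F)cc(F)cc21` gives 50 mg/kg, which lies within the scatter of the number for compound 2. Compound 1 `NC(=O)/C=C1\CCc2cc(F)cc(F)c21` gives 44 mg/kg, and the number for compound 2 stands above this one by more than the scatter. Compound 2 therefore holds the highest of the three numbers, although only its gap to compound 1 is beyond the scatter.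

Compound 4 `CCCNC(=O)/C=C1\CCc2ccc(F)cc21` is the next structure to be tested. It differs from compound 2 by propyl in place of isopropyl on an amide-type nitrogen, which places propyl in place of isopropyl on an amide-type nitrogen. The two have the same atoms, joined differently.

Going by the values given here, the only measured step is a 1.9-fold lower number from compound 2 to compound 3 (0.28 log units; within the scatter), and it is fluoro in place of hydrogen on an aromatic carbon. It therefore says nothing directly about this change. Among the compounds with values here, no measured step alters the group on the amide-type nitrogen alone, and compound 1 differs from compound 2 in more than one place. With no evidence for a shift in either direction, no step beyond the scatter is expected. The expected change is a 1.1-fold lower number from compound 2 to compound 4 (0.03 log units; within the scatter). For compound 4 the estimated value is 90 mg/kg, with an expected range from 45 mg/kg to 180 mg/kg.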

Compound 4, dose for half-maximal effect: > 100 mg/kg
Compound 4: a limit, no number; the forecaster's own chance of this, stated with the estimate: 5%; at least 1.1-fold (0.04 log units) between middle value and limit.
By their numbers in this assay, from the lowest: compounds 1, 3 and 2 (each within the scatter of the next, the first and the last beyond it). At a limit, above all of these: compound 4.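

In this assay compound 4 gives > 100 mg/kg, which is a limit of the assay and not a number. Among the compounds shown, this is the only step that alters the group on the amide-type nitrogen alone, and propyl in place of isopropyl reads as an at least 1.0-fold higher number from compound 2 to compound 4 (0.01 log units; that floor lies within the scatter), so the earlier compounds' silence on this position gives way to a floor that points to no lower number but does not by itself separate the two compounds. Going by these compounds, the size of the step stays unknown, and the reading ends at the edge of what the assay reports: the limit of > 100 mg/kg in this assay, at which 1 of the 4 values shown sits.

On these data alone, how far compound 4 really lies from compound 2 remains open, and with it whether exchanging isopropyl for propyl matters beyond the scatter at all. Also open, as far as these compounds go, is how this position would respond to a longer chain such as butyl, to a cyclopropyl group or to an ether-bearing chain on the amide-type nitrogen, and whether propyl would behave the same way on the core of compound 3.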